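A few compounds are considered here, and "the series" means these few. Any claim that something is new, unique, unknown or untested is made for them only; others in the source may bear on it.

Measured set in a functional assay on HeLa cells (Homo sapiens) for antiproliferative activity, read by CCK-8 assay, with a stated time of 48 h; on this read-out lower numbers stand for stronger inhibition and higher numbers for weaker inhibition:
Compound 1 `COc1ccc(/C=C\c2cc(OC)c(OC)c(OC)c2)cc1OCc1ccc(CN2CC[C@H](C(=O)O)C2)cc1` reaches only the assay limit, > 10000 nM.
Compound 2 `COc1ccc(/C=C\c2cc(OC)c(OC)c(OC)c2)cc1OCc1ccc(CN2CCCCC2C(=O)O)cc1` gives 14200 nM.
Compound 3 `COc1ccc(/C=C\c2cc(OC)c(OC)c(OC)c2)cc1OCc1ccc(CN2CC[C@H](O)C2)cc1` gives 10500 nM.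

Compound 2 carries the highest of the two numbers actually read; its nearest neighbour is compound 3, and the step of a 1.4-fold lower number from compound 2 to compound 3 (0.13 log units; within the scatter) stays within the scatter. The step that the limit leaves unreadable from compound 1 to compound 2 cannot be sized because compound 1 sits at the limit of > 10000 nM in this assay, at which 1 of the 3 values shown sits.

Compound 4 `COc1ccc(/C=C\c2cc(OC)c(OC)c(OC)c2)cc1OCc1ccc(CN[C@H](C(=O)O)[C@@H](C)O)cc1` differs from compound 2 by (1-carboxy-2-hydroxypropyl)amino in place of 2-carboxypiperidin-1-yl on a saturated chain carbon bound to an aromatic carbon. Only a 1.4-fold lower number from compound 2 to compound 3 (0.13 log units; within the scatter) is readable among the measured steps, and it shows no movement; the change to compound 4 keeps a carboxy and adds a hydroxy, so no shift beyond the scatter is expected in this assay, the expected step being a 1.2-fold lower number from compound 2 to compound 4 (0.07 log units; within the scatter). Compound 4 is estimated at 12000 nM, with a range from 6000 nM to 25000 nM.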

Compound 4, half-maximal inhibitory concentration: > 10000 nM
Compound 4: only a limit was reported (the forecaster's own chance of this, stated with the estimate: 40%); the middle value does not contradict the limit.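

Compound 4 gives only a limit, > 10000 nM, so its steps to compound 1, compound 2 and compound 3 cannot be read. Still open, from the compounds shown here alone, is whether any change on this saturated chain carbon moves the number beyond the scatter.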